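From Hydroxyethyl Amide to Free Acid at the Assay Limit

A few compounds are considered here, and "the series" means these few. Any claim that something is new, unique, unknown or untested is made for them only; others in the source may bear on it.

In a functional assay on A549 cells (Homo sapiens) for cytotoxicity, read by MTT assay, with a stated time of 72 h (a lower number here means a stronger inhibitor, a higher number a weaker inhibitor), compound 1 (`Cc1oc2ncnc(Nc3cccc(Cl)c3)c2c1C(=O)NCCO`) returns only a limit, > 1000000 nM. Compound 2 (`CCOC(=O)c1c(C)oc2ncnc(Nc3cccc(Br)c3)c12`) also returns only a limit, > 1000000 nM. Compound 3 (`CCOC(=O)c1c(C)oc2ncnc(Nc3ccc(OCc4ccc(C)cc4)cc3)c12`) likewise returns only a limit, > 1000000 nM. For the measured compounds named here, no number therefore places compound 1 relative to the other two, and no measured step is available. Compound 4 (`Cc1oc2ncnc(Nc3cccc(Cl)c3)c2c1C(=O)O`) keeps the core of compound 1 but carries hydroxy in place of (2-hydroxyethyl)amino on a carbonyl carbon. The expected a number no higher from compound 1 to compound 4 (the limit leaves the size open) is none beyond the scatter, with no direction favoured, and the reading may well remain a limit. Compound 4 is estimated at 1000000 nM, within an expected range of 300000 nM to 3000000 nM.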

Compound 4, half-maximal inhibitory concentration: 95500 nM
The estimate for compound 4 lay 10-fold (1.02 log units) above the measured number; measured number outside the range, below it.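

In this assay, for the compounds shown here, hydroxy in place of (2-hydroxyethyl)amino on the carbonyl carbon gives an at least 10-fold lower number from compound 1 to compound 4 (1.01 log units; beyond the scatter), the first sign that a change at this place can bring a reading off the limit. The true size of the step stays unknown because compound 1 gives only a limit: the limit of > 1000000 nM in this assay, at which 3 of the 4 values shown sit.

Going by these compounds, how a primary amide or a methyl ester on the same carbonyl carbon would read remains open. So does whether the carboxy group would give a measurable number with bromine in place of chlorine.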